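This account rests on a few compounds, and the source may have more. Where it says the series, first, only, none or still open, it means among the compounds named here.

Measured so far in a functional assay on A549 cells (Homo sapiens) for cytotoxicity, read by WST assay, with a stated time of 24 h; on this read-out higher numbers stand for weaker inhibition and lower numbers for stronger inhibition:

compound 1 `N#C/C(=C\c1cn(Cc2ccc(Cl)cc2)c2ccccc12)C(=O)c1c[nH]c2ccccc12`: > 50000 nM
compound 2 `COc1ccc2[nH]cc(/C=C(\C#N)C(=O)c3c[nH]c4ccc(OC)cc34)c2c1`: > 50000 nM
compound 3 `COc1ccc(Cn2cc(/C=C(\C#N)C(=O)c3c[nH]c4cc(OC)ccc34)c3ccccc32)cc1`: 37400 nM

Compound 1 reaches only a limit of this assay, > 50000 nM. Compound 2 likewise reaches only a limit, > 50000 nM. Among the compounds with values here, compound 3 is the one compound that gives a number, 37400 nM. Compound 2 thus stands at the edge of what this assay reports, and it shares that position with one other compound, as the limit of > 50000 nM in this assay, at which 2 of the 3 values shown sit, shows.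

Compound 4 `COc1ccc2[nH]cc(/C=C(\C#N)C(=O)c3c[nH]c4ccccc34)c2c1` differs from compound 2 in one place: hydrogen in place of methoxy on an aromatic carbon. Within the data shown here, no step between two measured compounds is available to size such a change, so the account leans only on where compound 2 stands. With compound 2 already at a limit, the step from compound 2 to compound 4 is expected to be none beyond the usual scatter, a number no higher from compound 2 to compound 4 (the limit leaves the size open). Compound 4 is therefore expected to give about 50000 nM in this assay, within a range from 20000 nM to 150000 nM, most likely again reported as a limit.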

Compound 4, half-maximal inhibitory concentration: 6600 nM
For compound 4 the middle estimate is 7.6-fold (0.88 log units) above the measured one; measured number below the stated range.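

In this assay, this aromatic carbon proves sensitive to what it carries: hydrogen in place of methoxy gives an at least 7.5-fold lower number from compound 2 to compound 4 (0.87 log units; beyond the scatter). The earlier compounds shown here gave no sign of this, and the pair now shows that a measurable number can be reached with a single change, while compound 4 keeps its other methoxy group and no group is added on a ring nitrogen. The step is a minimum and not a full size, since compound 2 sits at a limit: the limit of > 50000 nM in this assay, at which 2 of the 4 values shown sit.

The compounds shown leave open how fluorine, an amine or a longer chain on this carbon would compare with hydrogen. They also leave open whether replacing the methoxy that compound 4 keeps would move the number further, and whether this step would hold in compounds with a benzyl group on a ring nitrogen.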